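Amide aryl change on the cyclopentyloxy anisamide core

The source may hold more compounds than are shown below. What is called first, only, known or untested is meant among the compounds shown, and "the series" means these compounds.

Compound 1 `COc1ccc(C(=O)Nc2ccccc2Cl)cc1OC1CCCC1` is the reference; in an assay on isolated protein for inhibition of phosphodiesterase 4A (Sus scrofa) (on this read-out higher numbers stand for weaker inhibition and lower numbers for stronger inhibition), compound 1 gives 190 nM, the higher of the two numbers measured here. Compound 3 `COc1ccc(C(=O)Nc2c(Cl)c(F)nc(F)c2Cl)cc1OC1CCCC1` differs from compound 1 in several places at once. In this assay compound 3 gives 20 nM. Compound 2 `COc1ccc(C(=O)Nc2ccccc2Cl)cc1OC(=O)C1CCCC1` reaches only the limit of this assay, > 1000000 nM, as the measured values show in the limit of > 1000000 nM in this assay, at which 1 of the 3 values shown sits. Going by the values given here, the one-place step an at least 5200-fold higher number from compound 1 to compound 2 (3.72 log units; beyond the scatter) is the only measured step in the set, and it concerns the oxygen substituent, not the amide side.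

Compound 4 `COc1ccc(C(=O)Nc2ncccc2C)cc1OC1CCCC1` changes the amide side instead: 3-methylpyridin-2-yl in place of 2-chlorophenyl on an amide-type nitrogen. Among the compounds with values here, no measured step bears directly on this change. Within the data shown here, the only guide is that compound 3, which also replaces the 2-chlorophenyl on the amide-type nitrogen, sits lower than compound 1. A modest downward step, a 1.6-fold lower number from compound 1 to compound 4 (0.20 log units; within the scatter), is therefore expected, with wide uncertainty. Compound 4 is estimated at 120 nM in this assay, within 30 nM to 500 nM.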

Compound 4, half-maximal inhibitory concentration: 3100 nM
The estimate for compound 4 lay 26-fold (1.41 log units) below the measured number, and the stated range ends below it.
By their numbers in this assay, from the lowest: compound 3; then compound 1; then compound 4. At a limit, above all of these: compound 2.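

The amide side of the core proves sensitive in this assay: 3-methylpyridin-2-yl in place of 2-chlorophenyl on the amide-type nitrogen gives a 16-fold higher number from compound 1 to compound 4 (1.21 log units; beyond the scatter) and so marks a large loss of inhibition. Going by these compounds alone, this is the first measured one-place step on the amide side, and it shows that a replacement group with the same heavy-atom count can still cost much inhibition at this position. Nothing measured here explains the loss.

The change swaps the chlorine for a methyl and a ring carbon for a ring nitrogen in one move, and the compounds shown cannot separate these two parts. From the compounds shown here alone, how a plain phenyl, or a pyridinyl group without the methyl, would read on the same amide-type nitrogen remains open.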